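The compounds below may be only part of what the source reports. "The series", "measured", "known", "first", "only" and "open" are said of these compounds alone.

Of the compounds shown here, two of one shared core have been measured. In an assay on HEK293 cells for positive allosteric modulation of metabotropic glutamate receptor 5 (Homo sapiens), read by FLIPR, with a stated time of 1 h (on this read-out higher numbers stand for an effect only at larger amounts of compound and lower numbers for an effect already at smaller amounts), compound 1 `O=C1NCCc2nc(C#Cc3ccccc3)sc21` gives 112 nM, while compound 2 `CN1CCc2nc(C#Cc3ccccc3)sc2C1` gives 34 nM. Compound 2 therefore stands at the lowest of the two numbers, and its nearest neighbour, compound 1, sits at a number higher by more than the usual scatter of repeated measurements, so the difference between the two counts as real.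

The next compound, compound 3 `CC(C)S(=O)(=O)N1CCc2nc(C#Cc3ccccc3)sc2C1`, has not yet been measured. Its structure differs from compound 2 in a single place: isopropylsulfonyl in place of methyl on an amine nitrogen in a ring. Among the compounds with values here, no step between measured compounds involves this kind of exchange, so there is no directly comparable pair to lean on.

For compound 3 the expected step is a 2.4-fold higher number from compound 2 to compound 3 (0.37 log units; beyond the scatter), a somewhat higher number, with a good chance that it stays inside the scatter. The estimate for compound 3 is 80 nM, expected to fall between 20 nM and 320 nM.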

Compound 3, half-maximal effective concentration: > 10000 nM
Compound 3: a limit, no number; the forecaster's own chance of this, stated with the estimate: 5%; middle value at least 120-fold (2.09 log units) from the limit.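

In this assay compound 3 gives > 10000 nM, which is a limit of the assay and not a number: the limit of > 10000 nM in this assay, at which 1 of the 3 values shown sits.

From the compounds shown here alone, putting isopropylsulfonyl in place of methyl on the amine nitrogen in the ring brings an at least 290-fold higher number from compound 2 to compound 3 (2.46 log units; beyond the scatter), and this is a lower bound, so the true size of the step stays unknown. The earlier compounds shown here offered no step at all, whereas this one shows that a single exchange at this nitrogen can carry a compound of the shared core out of the range this read-out can report.

Going by these compounds, it stays open whether the sulfonyl part, the isopropyl part or the two together account for this step. Methylsulfonyl, acetyl or ethyl on the same nitrogen would help to tell these apart.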